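This account rests on a few compounds, and the source may have more. Where it says the series, first, only, none or still open, it means among the compounds named here.

Compound 3, `COc1ccc(N/C=C\C(=O)c2nc(-c3ccc(F)cc3)n3ccccc23)cc1OC`, was tested in a functional assay on BT-474 cells (Homo sapiens) for cytotoxicity, read by MTT assay, with a stated time of 48 h; a lower number here means a stronger inhibitor, a higher number a weaker inhibitor. In this assay compound 3 reaches only a limit, > 30000 nM, so no number is known for it. Two measured neighbours differ from it in one place each. Compound 1, `COc1ccc(N/C=C\C(=O)c2nc(-c3ccc(C(F)(F)F)cc3)n3ccccc23)cc1OC`, carries a trifluoromethyl where compound 3 carries fluoro; in this assay compound 1 likewise gives only a limit, > 30000 nM. Compound 2, `COc1ccc(N/C=C\C(=O)c2nc(-c3ccc(F)cc3)n3ccccc23)cc1`, lacks one of the two methoxy groups of compound 3; in this assay compound 2 gives 15700 nM. Among the measured compounds shown here, the first change gives a step that the two limits leave unreadable from compound 1 to compound 3, while adding the methoxy gives an at least 1.9-fold higher number from compound 2 to compound 3 (0.28 log units; that floor lies within the scatter). the limit of > 30000 nM in this assay, at which 2 of the 3 values shown sit, shows how little the present numbers can settle.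

Compound 4, `Cc1cc2cc(N/C=C\C(=O)c3nc(-c4ccc(F)cc4)n4ccccc34)ccc2[nH]1`, differs from compound 3 by 2-methyl-1H-indol-5-yl in place of 3,4-dimethoxyphenyl on an amine nitrogen. Neither measured step repeats this change. The nearest hint is the methoxy step from compound 2 to compound 3, which suggests that taking methoxy groups away, as happens here, may lower the number. Compound 4 is therefore expected to give a somewhat lower number than the limit of compound 3, the estimated step being an at least 2.1-fold lower number from compound 3 to compound 4 (0.33 log units; beyond the scatter). The estimate for compound 4 is 14000 nM, with a range from 4000 nM to 40000 nM, and a real chance that only a limit is reported again.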

Compound 4, half-maximal inhibitory concentration: > 30000 nM
Compound 4 was reported as a limit (the forecaster's own chance of this, stated with the estimate: 40%); middle value at least 2.1-fold (0.33 log units) from the limit.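

The new result shows that swapping the single benzene ring on the amine nitrogen for the two-ring 2-methyl-1H-indol-5-yl group, which brings in a hydrogen-bond donor, does not produce a readable number. In this assay, compound 4 gives only a limit, > 30000 nM, just as compound 3 does, so the step between them cannot be read, and neither can any other step that joins two limits. Against the 4-methoxyphenyl group of compound 2, the indole change gives an at least 1.9-fold higher number from compound 2 to compound 4 (0.28 log units; that floor lies within the scatter), so even this comparison does not show a real change, and what restricts the reading at this position is one shared limit: the limit of > 30000 nM in this assay, at which 3 of the 4 values shown sit.

On these data alone, it remains open whether a plain phenyl, a pyridine ring, or an aryl group carrying a carboxylic acid or a basic amine on the amine nitrogen would bring the values clearly under that limit. Among the compounds shown here, also open is whether trifluoromethyl in place of fluoro would change the number when the group on the amine nitrogen is the 4-methoxyphenyl of compound 2, the only compound here with a measured number.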